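The source may hold more compounds than are shown below. What is called first, only, known or untested is meant among the compounds shown, and "the series" means these compounds.

Measured compounds:
compound 1 `CC(=O)Nc1ccc(S(=O)(=O)NNC(=O)c2cccnc2Nc2ccc(Cl)cc2)cc1` — > 100000 nM
compound 2 `O=C(NNS(=O)(=O)c1ccc(F)cc1)c1cccnc1Nc1ccc(Cl)cc1Cl` — > 100000 nM

In a functional assay on T47D cells (Homo sapiens) for antiproliferative activity (a higher number here means that more compound is tolerated, a lower number that less compound is tolerated), compound 1 gives > 100000 nM, which is a limit of the measurement and not a number. Compound 2 likewise gives > 100000 nM, again a limit. Compound 1 thus sits at the limit of > 100000 nM in this assay, at which 2 of the 2 values shown sit, so nothing beyond that limit is known of it. Compound 3 `O=C(NNS(=O)(=O)c1ccc(Cl)cc1Cl)c1cccnc1Nc1ccc(Cl)cc1` differs from compound 1 by 2,4-dichlorophenyl in place of 4-acetamidophenyl on a sulfonyl sulfur. For the measured compounds named here, with no measured step to rest on, the step is expected to be a number no higher from compound 1 to compound 3 (the limit leaves the size open), none beyond the scatter, since both measured compounds sit at the limit. Compound 3 is expected at 100000 nM, within 30000 nM to 300000 nM.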

Compound 3, concentration lethal to 50% of the cells: > 100000 nM
Compound 3 gave a limit, no number; the forecaster's own chance of this, stated with the estimate: 75%; the middle value sits exactly at the limit.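

For the compounds shown here, compound 3 gives > 100000 nM, a limit and not a number, and compound 1 also stands at a limit, so no step between them can be read. The compounds shown leave open how 2,4-dichlorophenyl and 4-acetamidophenyl compare in this assay.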